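The source may report more compounds than this note shows. Statements on the series, on what has been measured and on what is new or still open speak of the compounds shown alone.

Compound 1 `Cc1cc(NC(=O)Nc2ccc(C(C)(C)C)cc2)c2ccccc2n1`: 20000 nM
Compound 2 `Cc1cc(NC(=O)Nc2ccc(C)c(Cl)c2)c2ccccc2n1`: > 25000 nM (limit)
Compound 3 `Cc1cc(NC(=O)Nc2ccccc2OC(F)(F)F)c2ccccc2n1`: > 25000 nM (limit)

In an ADME assay on BJ cells (Homo sapiens) for cytotoxicity, with a stated time of 72 h (a lower number here means that less compound is needed, a higher number that more compound is needed for the effect), compound 2 gives > 25000 nM, which is a limit and not a number. Compound 3 gives > 25000 nM, also a limit. Compound 2 stands at the limit of > 25000 nM in this assay, at which 2 of the 3 values shown sit. Compound 4 `Cc1cc(NC(=O)Nc2ccc(Cl)c(Cl)c2)c2ccccc2n1` has chloro in place of methyl on an aromatic carbon, ortho to a chloro group and para to a large group (chloro in place of methyl on an aromatic carbon). Going by the values given here, no measured step between compounds is available. Among the compounds with values here, the expectation rests on compound 1, which gives 20000 nM, the only number in the set. No change beyond the scatter is expected in this assay. The expected step is an at least 1.1-fold lower number from compound 2 to compound 4 (0.05 log units; that floor lies within the scatter). The estimate for compound 4 is 22000 nM, with an expected range of 11000 nM to 40000 nM.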

Compound 4, half-maximal effective concentration: 23000 nM
Estimate against measurement, compound 4: 1.0-fold (0.02 log units) below; measured number inside the range.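

In this assay, chloro in place of methyl on an aromatic carbon, ortho to a chloro group and para to a large group, gives an at least 1.0-fold lower number from compound 2 to compound 4 (0.03 log units; that floor lies within the scatter). Compound 4 gives 23000 nM, so with chloro at this position the read-out is a number and not a limit. Compound 2 remains a limit, so the step has only a floor: the limit of > 25000 nM in this assay, at which 2 of the 4 values shown sit.

From the compounds shown here alone, the true size of the step from methyl to chloro stays open. So does whether an amine or a methoxy group at this position would give a number or a limit.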